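Methyl in Place of Hydrogen: From Compound 1 to Compound 3

A few compounds are considered here, and "the series" means these few. Any claim that something is new, unique, unknown or untested is made for them only; others in the source may bear on it.

Compound 1 `C/N=C(/NC#N)NCCCCCCn1nc(-c2ccccc2)ccc1=O` in a functional assay on the whole organism (stomach) with Rattus norvegicus as the target (a higher number here means that more compound is needed for the effect, a lower number that less compound is needed), gives > 100 mg/kg, which is a limit of the assay and not a number.
Compound 2 `CN/C(=N/CCCCn1nc(-c2ccc(OC)cc2)ccc1=O)NC#N` in this assay gives > 100 mg/kg, which again is a limit and not a number.

Both measured compounds therefore sit at the same point: the limit of > 100 mg/kg in this assay, at which 2 of the 2 values shown sit. Among the measured compounds shown here, no step between them is given, so nothing can be said of one against the other beyond the fact that each stands at that limit. Compound 1 stands there as well, with no number of its own.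

Compound 3 `CC/N=C(/NC#N)NCCCCCCn1nc(-c2ccccc2)ccc1=O` differs from compound 1 in one place:
methyl in place of hydrogen on a saturated chain carbon bound to a double-bonded nitrogen

For the measured compounds named here, since compound 1 gives only a limit, no measured step is available to anchor the change, and the methyl is a small addition to a chain. The step in this assay is expected to be none beyond the scatter, and the estimate is a step that the limit leaves unreadable from compound 1 to compound 3. Compound 3 is accordingly expected to give about 150 mg/kg, within a range of 50 mg/kg to 500 mg/kg, with a strong chance that the assay again reports only a limit.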

Compound 3, dose for half-maximal effect: > 100 mg/kg
Compound 3 was reported as a limit (the forecaster's own chance of this, stated with the estimate: 80%); the middle value is on the limit's open side.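

Compound 1 and compound 3 both stand at a limit and not at a number, so no step from one to the other can be read and the methyl in place of hydrogen has no size here: the limit of > 100 mg/kg in this assay, at which 3 of the 3 values shown sit.

The compounds shown leave open what dose of any of them would give the half-maximal effect in this assay.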